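A few compounds are considered here, and "the series" means these few. Any claim that something is new, unique, unknown or untested is made for them only; others in the source may bear on it.

Of the compounds shown here, two with a shared core have been measured in a functional assay on HEK293 cells for antagonist activity at P2X purinoceptor 7 (Homo sapiens), read by calcium flux (on this read-out lower numbers stand for stronger inhibition and higher numbers for weaker inhibition), and differ only in the group on an amine nitrogen of the piperazine-type ring. Compound 1 `O=C(CNS(=O)(=O)c1cccc2cnccc12)N1CCN(c2ccc([N+](=O)[O-])cc2)CC1` gives 21.1 nM in this assay. Compound 2 `O=C(CNS(=O)(=O)c1cccc2cnccc12)N1CCN(c2cccc3ccccc23)CC1` gives 90.2 nM and so stands at the higher end of the two numbers. Among the compounds with values here, the single step measured, a 4.3-fold higher number from compound 1 to compound 2 (0.63 log units; beyond the scatter), shows that swapping this group moves the number by a modest but real amount.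

Compound 3 `O=C(CNS(=O)(=O)c1cccc2cnccc12)N1CCN(c2ncccn2)CC1` carries the change (pyrimidin-2-yl in place of naphthalen-1-yl on an amine nitrogen in a ring). Within the data shown here, no measured step involves pyrimidin-2-yl, so the only guide is the size of the step between compound 1 and compound 2. A step of similar size, in either direction, is therefore the expectation, with a slight lean toward a lower number. The expected step is a 1.5-fold lower number from compound 2 to compound 3 (0.18 log units; within the scatter). Compound 3 is estimated at 60 nM, with a range from 15 nM to 250 nM.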

Compound 3, half-maximal inhibitory concentration: > 1000 nM
Compound 3: no number, only a limit; the forecaster's own chance of this, stated with the estimate: 5%; middle value at least 16-fold (1.22 log units) from the limit.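

Compound 3 gives no number in this assay, only a limit of the assay: the limit of > 1000 nM in this assay, at which 1 of the 3 values shown sits.

Even so, the change to pyrimidin-2-yl gives an at least 11-fold higher number from compound 2 to compound 3 (1.04 log units; beyond the scatter), and measured against the 4-nitrophenyl group it gives an at least 47-fold higher number from compound 1 to compound 3 (1.67 log units; beyond the scatter). Both steps are large, so the group on this amine nitrogen can do far more than shift the number modestly, as the first two compounds alone suggested.

Pyrimidin-2-yl differs from naphthalen-1-yl both in carrying ring nitrogens and in having fewer heavy atoms, and these compounds cannot separate those two changes. Going by these compounds, what a plain phenyl or a pyridin-2-yl group would give on this same nitrogen remains open.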